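Ester versus acid in a small benzyl series

A few compounds are considered here, and "the series" means these few. Any claim that something is new, unique, unknown or untested is made for them only; others in the source may bear on it.

Values in a functional assay on cells (Platelet, Homo sapiens) for inhibition; on this read-out higher numbers stand for weaker inhibition and lower numbers for stronger inhibition:
- compound 1 `CCOC(=O)c1ccc(-c2nn(Cc3ccccc3Cl)c3ccccc23)cc1`: 230 nM
- compound 2 `CCOC(=O)c1cccc(-c2nn(Cc3ccccc3)c3ccccc23)c1`: > 10000 nM (a limit of the assay)
- compound 3 `O=C(O)c1ccc(-c2nn(Cc3ccccc3)c3ccccc23)cc1`: > 10000 nM (a limit of the assay)

Compound 3, the free carboxylic acid, has no numerical value: it stands at > 10000 nM, which is a limit, and this is the limit of > 10000 nM in this assay, at which 2 of the 3 values shown sit. Among the compounds with values here, no two measured compounds differ in one place only, so the series offers no measured step to scale from.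

The next compound is compound 4 `CC(C)OC(=O)c1ccc(-c2nn(Cc3ccccc3)c3ccccc23)cc1`, which has isopropyl in place of hydrogen on an oxygen next to a carbonyl group, turning carboxy into isopropoxycarbonyl: isopropyl in place of hydrogen on an oxygen next to a carbonyl group.

Among the measured compounds, only compound 1, also an ester, gives a number in this assay, namely 230 nM. Compound 2 goes against any reading that an ester is enough, as it is also an ester and gives > 10000 nM, a limit of the assay.

A step beyond the scatter toward stronger inhibition is therefore expected, though with little confidence, and compound 4 may well remain at the limit. The expected at least 4.0-fold lower number from compound 3 to compound 4 (0.60 log units; beyond the scatter) is only a rough estimate, given the limit at its starting point. For compound 4 the estimated value is 2500 nM, with an expected range from 400 nM to 10000 nM.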

Compound 4, half-maximal inhibitory concentration: > 10000 nM
Compound 4 gave a limit, no number; the forecaster's own chance of this, stated with the estimate: 40%; middle value at least 4.0-fold (0.60 log units) away from the limit.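

In this assay compound 4 gives > 10000 nM, a limit of the assay. Compound 3 also stands at a limit, so no step between compound 3 and compound 4 can be read: the limit of > 10000 nM in this assay, at which 3 of the 4 values shown sit.

The compounds shown leave open whether isopropyl in place of hydrogen on that oxygen changes inhibition at all.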